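The compounds below may be only part of what the source reports. "The series", "measured", "known", "first", "only" and "open" are said of these compounds alone.

Two compounds share a core in which a trifluoromethyl-bearing hydroxy amide is joined to a sulfonyl-linked aryl pair. Compound 1 (`CC(O)(C(=O)Nc1ccc(S(=O)(=O)c2cccc(F)c2)cc1)C(F)(F)F`) and compound 2 (`CC(O)(C(=O)Nc1ccc(S(=O)(=O)c2ccccc2)c(C#N)c1)C(F)(F)F`) have both been tested in a functional assay (Cavia porcellus) with sulfonylurea receptors; K-ATP channels (Homo sapiens) as the target; on this read-out higher numbers stand for weaker inhibition and lower numbers for stronger inhibition. Compound 1 gives 3400 nM in this assay, and compound 2 gives 3800 nM in this assay; these two values lie within the usual scatter of each other, so compound 1 is not set apart from compound 2 by the numbers at hand. Compound 3 (`CC(O)(C(=O)Nc1ccc(S(=O)(=O)c2ccc(Br)cc2)cc1)C(F)(F)F`) has not yet been measured. It differs from compound 1 in one place: 4-bromophenyl in place of 3-fluorophenyl on a sulfonyl sulfur. Among the compounds with values here, no measured pair shows how this kind of exchange moves the read-out, so there is no basis for expecting a step beyond the scatter in either direction. Compound 3 is therefore expected to give about 3000 nM in this assay, within a range of 1000 nM to 9000 nM, an expected step of a 1.1-fold lower number from compound 1 to compound 3 (0.05 log units; within the scatter).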

Compound 3, half-maximal inhibitory concentration: > 30000 nM
Compound 3: only a limit was reported; the forecaster's own chance of this, stated with the estimate: 5%; middle value at least 10-fold (1.00 log units) away from the limit.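

The aryl group on the sulfonyl sulfur proves sensitive in this assay: 4-bromophenyl in place of 3-fluorophenyl gives an at least 8.8-fold higher number from compound 1 to compound 3 (0.94 log units; beyond the scatter), and a higher number here means weaker inhibition. The earlier compounds shown here offered no step between compounds differing in one place, so they could not show that a single exchange at this position moves the read-out beyond the scatter. The true size of this step stays undefined, as it rests on a limit and not on a number: the limit of > 30000 nM in this assay, at which 1 of the 3 values shown sits.

The two groups differ both in the halogen and in its position on the phenyl ring, and the compounds shown do not separate these two changes, which a 4-fluorophenyl or a 3-bromophenyl group could do. As far as these compounds go, how a 4-methoxyphenyl or 4-aminophenyl group would read on the same sulfur also remains open.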